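Amide variation on a shared core: compound 2 to 4

The source may report more compounds than this note shows. Statements on the series, on what has been measured and on what is new or still open speak of the compounds shown alone.

Three compounds share one core and differ only in the amide part. Compound 1 `CC(C)c1c(C(=O)NCc2ccccc2)nn(-c2ccc(F)cc2)c1OC[C@@H](O)C[C@@H](O)CC(=O)O` gives 3.8 nM in an assay on microsomes from liver for inhibition of 3-hydroxy-3-methylglutaryl-coenzyme A reductase (Rattus norvegicus); a lower number here means a stronger inhibitor, a higher number a weaker inhibitor. Compound 2 `CCN(Cc1ccccc1)C(=O)c1nn(-c2ccc(F)cc2)c(OC[C@@H](O)C[C@@H](O)CC(=O)O)c1C(C)C` gives 14 nM in this assay, and compound 3 `Cc1ccc(CNC(=O)c2nn(-c3ccc(F)cc3)c(OC[C@@H](O)C[C@@H](O)CC(=O)O)c2C(C)C)cc1` gives 15 nM in this assay. Compound 2 stands second highest of the three numbers: its nearest neighbour is compound 3, a 1.1-fold higher number from compound 2 to compound 3 (0.03 log units; within the scatter), and its furthest is compound 1, a 3.7-fold higher number from compound 1 to compound 2 (0.57 log units; beyond the scatter).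

Compound 4 `COc1cccc(CNC(=O)c2nn(-c3ccc(F)cc3)c(OC[C@@H](O)C[C@@H](O)CC(=O)O)c2C(C)C)c1` is not yet measured. Against compound 2 the change is (3-methoxybenzyl)amino in place of benzyl(ethyl)amino on a carbonyl carbon.

Going by the values given here, two measured steps bear on this. First, a 3.7-fold higher number from compound 1 to compound 2 (0.57 log units; beyond the scatter), so going back from the benzyl(ethyl)amino to an amide-type nitrogen bearing hydrogen would, read in reverse, point toward a lower number. Second, a 3.9-fold higher number from compound 1 to compound 3 (0.60 log units; beyond the scatter), so a substituent on the aromatic ring of the benzyl group pointed toward a higher number. Among the compounds with values here, compound 4 combines both kinds of change, and the closest precedent is a 1.1-fold higher number from compound 2 to compound 3 (0.03 log units; within the scatter), where the same pair of changes left the number where it was. On that basis no step beyond the scatter is expected in this assay from compound 2 to compound 4, with the substituent on the ring differing in kind from compound 3 as the main uncertainty.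

For compound 4 the expected value in this assay is 11 nM, within 4 nM to 30 nM, which means an expected step of a 1.3-fold lower number from compound 2 to compound 4 (0.10 log units; within the scatter).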

Compound 4, half-maximal inhibitory concentration: 16 nM
Compound 4: middle estimate off by 1.5-fold (0.16 log units), on the low side; measured number inside the range.
By their numbers in this assay, from the lowest: compound 1; then compounds 2, 3 and 4 (each within the scatter of the next).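

In this assay, a methoxy group on the ring of the benzyl amide gives a 4.2-fold higher number from compound 1 to compound 4 (0.62 log units; beyond the scatter) and so, like the methyl group of compound 3, a ring substituent of a second kind stands beyond the scatter from the plain benzyl amide. The exchange of 4-methylphenyl for 3-methoxyphenyl gives a 1.1-fold higher number from compound 3 to compound 4 (0.03 log units; within the scatter) and the exchange of benzyl(ethyl)amino for (3-methoxybenzyl)amino gives a 1.1-fold higher number from compound 2 to compound 4 (0.06 log units; within the scatter) so that these two comparisons do not separate compound 4 from compound 2 or compound 3. Among the four compounds, compound 1 alone stands apart, while ethyl on the amide-type nitrogen and either ring substituent cannot be told apart in this series. No measurement shown offers an explanation for this grouping.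

Open, on these data alone, is whether chlorine or a carboxylic acid on the benzyl ring, or a longer chain joining the amide nitrogen to the ring, would fall with this group or closer to compound 1. Also open, as far as these compounds go, is how ethyl on the amide nitrogen and a ring substituent behave when carried together on one compound.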